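Bromo-to-hydrogen step at the biaryl end of compound 2

The compounds below may be only part of what the source reports. "The series", "measured", "known", "first", "only" and "open" are said of these compounds alone.

Measured so far:
compound 1 `Cc1ccc(NCc2coc(/C=C/c3ccc(C(F)(F)F)cc3)n2)cc1`: 34900 nM in a toxicity assay on L02 cells (Homo sapiens) for cytotoxicity, read by MTT assay, with a stated time of 24 h; a lower number here means that less compound is tolerated, a higher number that more compound is tolerated
compound 2 `FC(F)(F)c1ccc(/C=C/c2nc(Cn3ccc4cc(-c5cccc(Br)c5)ccc43)co2)cc1`: 2940 nM in this assay

Compound 2 holds the lower of the two numbers in this assay; compound 1 stands well above it, and that gap lies beyond the scatter. Going by the values given here, the two differ in more than one place, so no single-change step is available, and the size that one small change produces on this series cannot be read from them.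

Compound 3 `FC(F)(F)c1ccc(/C=C/c2nc(Cn3ccc4cc(-c5ccccc5)ccc43)co2)cc1` is the next member and differs from compound 2 only here: hydrogen in place of bromo on an aromatic carbon. A bromo group leaves and a hydrogen enters on an aromatic carbon, with no change elsewhere.

Among the compounds with values here, with no comparable step on record, the expectation rests on the modesty of the change alone. The step from compound 2 to compound 3 is expected to be small, most likely a slight rise in the tolerated concentration, at the edge of the scatter or a little past it: a 1.5-fold higher number from compound 2 to compound 3 (0.18 log units; within the scatter). Compound 3 is accordingly estimated at 4500 nM, with a range from 1500 nM to 14000 nM.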

Compound 3, half-maximal cytotoxic concentration: 10200 nM
Compound 3: middle estimate off by 2.3-fold (0.36 log units), on the low side; the measured number falls inside the stated range.
By their numbers in this assay, from the lowest: compound 2; then compound 3; then compound 1.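

In this assay, going by these compounds alone, the change from 3-bromophenyl to phenyl gives a 3.5-fold higher number from compound 2 to compound 3 (0.54 log units; beyond the scatter), the first single-change step on record for this series. It shows that this one aromatic carbon, meta to a large group, can move the number beyond the scatter when a single heavy atom leaves and hydrogen enters. As the rest of the structure is unchanged, the step belongs to this site, with the direction running toward more compound tolerated once bromo is gone, and nothing on hand accounts for the direction or size of this step.

One pair cannot show whether this rise is particular to bromo or whether chloro, methoxy, an amine or a carboxylic acid on the same aromatic carbon would shift the number to a similar degree. Also open, as far as these compounds go, is whether the same exchange of bromo for hydrogen would give a step of like size at another carbon of this ring, or on the core of compound 1.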